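The source may hold more compounds than are shown below. What is called first, only, known or untested is meant among the compounds shown, and "the series" means these compounds.

Of the compounds shown here, two built on a shared core have been measured so far. In a functional assay on MIA PaCa-2 cells (Homo sapiens) for cytotoxicity, read by fluorescence, with a stated time of 48 h (a higher number here means that more compound is needed for the effect, a lower number that less compound is needed), compound 1 `CC(C)=CCC/C(C)=C/CC/C(C)=C/CSC[C@H](NC(=O)CCCCCN1CCN(C)CC1)C(=O)N1CCCC1` gives 6000 nM and compound 2 `CC(C)=CCC/C(C)=C/CC/C(C)=C/CSC[C@H](NC(=O)CCCCCN1CCCC1)C(=O)NC1CCCCCC1` gives 6800 nM. These two values lie within the usual scatter of each other, so compound 2 stands level with compound 1 on the numbers available, and neither can be ranked above the other.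

The next structure is compound 3 `CC(C)=CCC/C(C)=C/CC/C(C)=C/CSC[C@H](NC(=O)CCCCCN1CCCC1)C(=O)N1CCCC1`, which departs from compound 2 in one place. On a carbonyl carbon, pyrrolidin-1-yl takes the place of cycloheptylamino: pyrrolidin-1-yl in place of cycloheptylamino on a carbonyl carbon. Among the compounds with values here, no measured pair shows this change on its own, so the expectation rests on indirect evidence. Compound 1 also carries the (pyrrolidin-1-yl)carbonyl and gives 6000 nM, although it differs from compound 3 elsewhere in the structure. No step beyond the scatter is therefore expected in this assay, and no firm direction can be assigned. The expected change amounts to a 1.1-fold higher number from compound 2 to compound 3 (0.04 log units; within the scatter). For compound 3 the estimated value is 7500 nM, with an expected range from 3500 nM to 16000 nM.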

Compound 3, half-maximal effective concentration: 10800 nM
Compound 3: the middle estimate sits 1.4-fold (0.16 log units) below what was measured, and the stated range covers the measured number.
By their numbers in this assay, from the lowest: compounds 1, 2 and 3 (each within the scatter of the next).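

In this assay, the change from cycloheptylamino to pyrrolidin-1-yl on a carbonyl carbon can now be read on its own, and it comes to a 1.6-fold higher number from compound 2 to compound 3 (0.20 log units; within the scatter); the seven-membered carbon ring and the amide hydrogen can thus leave this place without a step beyond the scatter. The other end of the molecule can also be read for the first time: pyrrolidin-1-yl in place of 4-methylpiperazin-1-yl on a saturated chain carbon, five bonds along the chain from a carbonyl carbon, gives a 1.8-fold higher number from compound 1 to compound 3 (0.26 log units; within the scatter), so neither place has yet shown a step beyond the scatter in this assay. No measurement available here bears on why these two steps are of this size.

From the compounds shown here alone, both changes replace one ring with another, so it remains open whether an open-chain group such as dimethylamino at the chain end, or a carboxylic acid at the carbonyl carbon, would also stay within the scatter. All three compounds share the same chain leading to the terminal amine, which leaves open how a shorter or longer chain would read.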